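Swapping One Aryl Group on a Shared Core

The source may hold more compounds than are shown below. What is called first, only, known or untested is meant among the compounds shown, and "the series" means these compounds.

Two compounds have so far been run in a functional assay on the whole organism (strain albino) with Rattus norvegicus as the target, read by paw edema, with stated times of 1 h and 4 h, at a dose of 50 mg/kg by the oral route; on this read-out higher numbers stand for a stronger effect at the one dose given and lower numbers for a weaker effect. Compound 1 `COc1ccc(Cl)cc1C(=O)Nc1ccc(C2=NNC(c3ccccc3[N+](=O)[O-])C2)cc1` gives 90.9% in this assay. Compound 2 `COc1ccc(C2CC(c3ccc(NC(=O)c4cc(Cl)ccc4OC)cc3)=NN2C(C)=O)cc1` gives 90.2% in this assay. Compound 2 stands lowest of the two numbers, but its nearest neighbour, compound 1, sits within the scatter of it, so the two cannot be told apart.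

Compound 3 `COc1ccc(Cl)cc1C(=O)Nc1ccc(C2=NN(C(C)=O)C(c3ccccc3[N+](=O)[O-])C2)cc1` has not yet been measured. It differs from compound 2 in one place: 2-nitrophenyl in place of 4-methoxyphenyl on a saturated ring carbon. Within the data shown here, no step between two measured compounds is available to lean on. Still, compound 1 already carries the 2-nitrophenyl on its saturated ring carbon and gives 90.9%, so the step of a number 0.2 percentage points lower from compound 2 to compound 3 (within the scatter) is expected to stay within the scatter, in no particular direction. Compound 3 is therefore estimated at 90%, within a range from 80% to 97%.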

Compound 3, a percentage reported as activity, at one dose (the size of the read-out at that dose, not a potency): 96.2%
The estimate for compound 3 lay 6.2 percentage points below the measured number, and the stated range covers the measured number.
By their numbers in this assay, from the lowest: compounds 2, 1 and 3 (each within the scatter of the next).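

In this assay, 2-nitrophenyl in place of 4-methoxyphenyl on the saturated ring carbon gives a number 6 percentage points higher from compound 2 to compound 3 (within the scatter), so with the acetyl group present, these two aryl groups cannot be told apart at this position. Acetyl in place of hydrogen on the amine nitrogen in the ring gives a number 5.3 percentage points higher from compound 1 to compound 3 (within the scatter), so with 2-nitrophenyl on the ring carbon, this second change cannot be told from the scatter either. Nothing measured here gives a reason for either result.

Still open, as far as these compounds go, is whether a non-aryl group on the saturated ring carbon, such as methyl or a carboxylic acid, would give a similar number. Open too, from the compounds shown here alone, is whether a longer chain than acetyl on the ring nitrogen, such as butanoyl, would do the same.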